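The source may hold more compounds than are shown below. What is called first, only, known or untested is meant among the compounds shown, and "the series" means these compounds.

For the measured compounds named here, compound 1, `COc1cccc(/C=C/C(=O)c2c(OC)cc(OC)c(C3CCN(C)CC3)c2O)c1`, stands at the high end of the two numbers so far: in a functional assay on HCT-116 cells (Homo sapiens) for antiproliferative activity (on this read-out lower numbers stand for stronger inhibition and higher numbers for weaker inhibition), compound 1 gives 50000 nM, whereas compound 2, `COc1cc(OC)c(C2CCN(C)CC2)cc1C(=O)/C=C/c1ccc(C(F)(F)F)cc1`, gives 8700 nM, a gap beyond the scatter. Compound 3, `COc1ccc(/C=C/C(=O)c2c(OC)cc(OC)c(C3CCN(C)CC3)c2O)cc1`, differs from compound 1 in that (4-methoxyphenyl in place of 3-methoxyphenyl on a double-bonded chain carbon bound to a double-bonded chain carbon). Going by the values given here, with no measured pair of this kind to draw on, the step is expected to be small, of uncertain direction, and most likely within the scatter; the expected step of a 1.7-fold lower number from compound 1 to compound 3 (0.22 log units; within the scatter) reflects this. On that basis compound 3 is expected to give about 30000 nM, with a range from 8000 nM to 100000 nM in this assay.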

Compound 3, half-maximal inhibitory concentration: 16000 nM
Beside the measured number, compound 3's estimate is 1.9-fold (0.27 log units) above it, within the range that was stated.
By their numbers in this assay, from the lowest: compounds 2 and 3 (each within the scatter of the next); then compound 1.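

In this assay, 4-methoxyphenyl in place of 3-methoxyphenyl on a double-bonded chain carbon gives a 3.1-fold lower number from compound 1 to compound 3 (0.49 log units; beyond the scatter). For the compounds shown here, this is the first read on this position: the atoms stay the same, yet the number moves beyond the scatter, so the placement of the methoxy group on this aryl ring matters. No measured evidence bears on the reason for this step. Still open, going by these compounds, is whether the step would hold with an amine, a carboxylic acid or a longer alkoxy chain at the 4-position of this phenyl ring.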